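Small aryl swap on the anilino arm of a trifluoromethyl series

A few compounds are considered here, and "the series" means these few. Any claim that something is new, unique, unknown or untested is made for them only; others in the source may bear on it.

Compound 1 `COc1cc(Nc2ncc(C(F)(F)F)c(N3Cc4cccc(N(C)S(C)(=O)=O)c4C3)n2)cc(OC)c1` is the reference point here. Going by the values given here, in a functional assay on A549 cells (Homo sapiens) for antiproliferative activity, read by spectrophotometry, with a stated time of 2 days (on this read-out higher numbers stand for weaker inhibition of growth and lower numbers for stronger inhibition of growth), compound 1 gives 24800 nM, the highest of the three numbers measured so far. Compound 3 `CN(c1cccc2c1CN(c1nc(Nc3cccc(Oc4ccccc4)c3)ncc1C(F)(F)F)C2)S(C)(=O)=O` gives 19000 nM in this assay, which sits within the usual scatter of the value for compound 1, so the two cannot be told apart. Among the compounds with values here, compound 2 `CC(=O)N1CCN(c2ccc(Nc3ncc(C(F)(F)F)c(N4Cc5cccc(N(C)S(C)(=O)=O)c5C4)n3)cc2)CC1` gives 1300 nM in this assay, a gap to compound 1 that lies well beyond the scatter; it is the only member of the set in a clearly different range.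

Compound 4 `Cc1cc(C)cc(Nc2ncc(C(F)(F)F)c(N3Cc4cccc(N(C)S(C)(=O)=O)c4C3)n2)c1` is not yet measured. It differs from compound 1 in one place: 3,5-dimethylphenyl in place of 3,5-dimethoxyphenyl on a nitrogen on an aromatic ring. Within the data shown here, no pair of measured compounds shares this difference, so there is no step to lean on, and the change is confined to the substituents of one phenyl ring on the anilino arm.

The step of a 1.2-fold lower number from compound 1 to compound 4 (0.09 log units; within the scatter) is expected to fall within the scatter, with no clear direction. Compound 4 is therefore expected to give about 20000 nM in this assay, most likely between 6000 nM and 60000 nM.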

Compound 4, concentration for 50% growth inhibition: > 30000 nM
Compound 4 was reported as a limit; the forecaster's own chance of this, stated with the estimate: 10%; middle value at least 1.5-fold (0.17 log units) away from the limit.
By their numbers in this assay, from the lowest: compound 2; then compounds 3 and 1 (each within the scatter of the next). At a limit, above all of these: compound 4.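

Going by these compounds alone, this is the first one-place step, and it falls on the phenyl ring of the anilino arm. Compound 4 is reported only as a limit, > 30000 nM, in this assay, and not as a number: the limit of > 30000 nM in this assay, at which 1 of the 4 values shown sits. The step reads an at least 1.2-fold higher number from compound 1 to compound 4 (0.08 log units; that floor lies within the scatter), so replacing 3,5-dimethoxyphenyl with 3,5-dimethylphenyl, which takes out both oxygens and leaves carbon only, gives no sign of stronger inhibition of growth at this place.

On these data alone, how far compound 4 lies past the limit stays open, so the true size of the step cannot be read. Also open, as far as these compounds go, is whether an amine or a carboxylic acid on this phenyl ring, in place of the methoxy or methyl groups, would shift the number in either direction.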